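The compounds below may be only part of what the source reports. "The series", "measured", "known", "first", "only" and "open" are said of these compounds alone.

Measured in a toxicity assay (Homo sapiens) for cytotoxicity; a higher number here means that more compound is needed for the effect, a lower number that less compound is needed:
compound 1 `Nc1nc(F)nc2c1ncn2[C@@H]1O[C@H](CO)C=C1F`: > 100000 nM (a limit)
compound 2 `Nc1nc(Cl)c2ncn([C@@H]3O[C@H](CO)C=C3F)c2n1`: 77400 nM; 98800 nM (2 entries)
compound 3 `Nc1nc(O)c2ncn([C@@H]3O[C@H](CO)C=C3F)c2n1`: > 100000 nM; > 100000 nM (2 entries) (a limit)

Compound 1 has no exact number, only a limit: > 100000 nM. Compound 4 `Nc1nc(N)c2ncn([C@@H]3O[C@H](CO)C=C3F)c2n1` keeps the shared core but has amino in place of fluoro on an aromatic carbon, between two ring nitrogen atoms (amino in place of fluoro on an aromatic carbon). Among the compounds with values here, no measured pair shows the effect of a single change. Compound 3 also reaches only a limit, > 100000 nM; > 100000 nM (2 entries). Compound 2 alone gives numbers, 77400 nM; 98800 nM (2 entries). On this basis, no shift beyond the scatter is expected in this assay, and the expected step is a number no higher from compound 1 to compound 4 (the limit leaves the size open). For compound 4, the estimated value is 100000 nM, with an expected range from 40000 nM to 200000 nM.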

Compound 4, half-maximal effective concentration: > 100000 nM
Compound 4 gave a limit, no number (the forecaster's own chance of this, stated with the estimate: 70%); the middle value sits exactly at the limit.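

Compound 1 and compound 4 each give only a limit in this assay, so no step can be read between them. The compounds shown leave open whether amino in place of fluoro changes the concentration needed for cytotoxicity.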